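A few compounds are considered here, and "the series" means these few. Any claim that something is new, unique, unknown or untested is made for them only; others in the source may bear on it.

Notes on the series. In a functional assay on HeLa cells (Homo sapiens) for inhibition, read by sulforhodamine B assay (on this read-out higher numbers stand for weaker inhibition and lower numbers for stronger inhibition), compound 1 (`CCc1ccc(NC2=CC(=O)c3nc4n(c3C2=O)[C@H]2OC[C@@H](O)[C@H]2OC4)cc1`) gives 3990 nM with 4-ethylphenyl on the amine nitrogen. Compound 2 (`O=C1C=C(NC2CCCC2)C(=O)c2c1nc1n2[C@H]2OC[C@@H](O)[C@H]2OC1`) reads > 16000 nM and this is a limit of the assay, not a number. Compound 3 (`O=C1C=C(Nc2ccc(C(F)(F)F)cc2)C(=O)c2c1nc1n2[C@H]2OC[C@@H](O)[C@H]2OC1`) keeps the rest of compound 2 and changes one group (4-(trifluoromethyl)phenyl in place of cyclopentyl on an amine nitrogen) with 4-(trifluoromethyl)phenyl in place of cyclopentyl on an amine nitrogen. Within the data shown here, one measured step bears on this: cyclopentyl in place of 4-ethylphenyl on that nitrogen gave an at least 4.0-fold higher number from compound 1 to compound 2 (0.60 log units; beyond the scatter) and so lay beyond the scatter. Returning to a phenyl ring there is expected to lower the number in this assay by a step of similar size. On these data alone, the true size stays open, as compound 2 has only a limit. The expected step is an at least 4.0-fold lower number from compound 2 to compound 3 (0.60 log units; beyond the scatter) on this reasoning. For compound 3 the estimate is 4000 nM with an expected range from 1500 nM to 12000 nM on the same reasoning.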

Compound 3, half-maximal inhibitory concentration: > 8000 nM
Compound 3 ended at the assay's limit; the forecaster's own chance of this, stated with the estimate: 15%; middle value at least 2.0-fold (0.30 log units) away from the limit.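

Compound 3 gives only a limit of the assay, not a number: the limit of > 8000 nM in this assay, at which 1 of the 3 values shown sits.

Trifluoromethyl in place of ethyl on an aromatic carbon gives an at least 2.0-fold higher number from compound 1 to compound 3 (0.30 log units; that floor lies within the scatter), so a loss against compound 1 is not established, yet a six-membered aromatic ring on the amine nitrogen does not alone secure a measured number in this assay. Compound 2 and compound 3 both stand at limits, the step between them cannot be read, and the order of cyclopentyl and 4-(trifluoromethyl)phenyl stays undecided.

Open, on these data alone, is how an unsubstituted phenyl, 4-methoxyphenyl or 4-chlorophenyl on the amine nitrogen would read against compound 1. Also open, as far as these compounds go, is whether a longer chain, as in 4-propylphenyl, would give a number rather than a limit.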